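Swapping trifluoromethyl for amino on the anilino ring

A few compounds are considered here, and "the series" means these few. Any claim that something is new, unique, unknown or untested is made for them only; others in the source may bear on it.

Of the compounds shown here, three sharing one core have been tested in a functional assay on K562 cells (Homo sapiens) for antiproliferative activity, read by CellTiter-Glo and CCK-8 assay, with a stated time of 72 h; on this read-out lower numbers stand for stronger inhibition of growth and higher numbers for weaker inhibition of growth. Compound 1 `Cc1ccc(NC(=O)c2cccc(C(F)(F)F)c2)cc1N1Cc2cnc(Nc3ccc(C)c(C(F)(F)F)c3)nc2N(C)C1=O` gives 29 nM. Compound 2 `Cc1ccc(NC(=O)c2cccc(C(F)(F)F)c2)cc1N1Cc2cnc(O[C@H]3CCN(C(=O)OC(C)(C)C)C3)nc2N(C)C1=O` gives 30 nM, and compound 3 `Cc1ccc(NC(=O)c2cccc(C(F)(F)F)c2)cc1N1Cc2cnc(OC3CCN(C(=O)OC(C)(C)C)CC3)nc2N(C)C1=O` gives 29 nM. On these numbers compound 1 sits level with compound 3 at the digits shown, and its gap to compound 2 lies within the scatter, so the three cannot be told apart.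

Compound 4 `Cc1ccc(Nc2ncc3c(n2)N(C)C(=O)N(c2cc(NC(=O)c4cccc(C(F)(F)F)c4)ccc2C)C3)cc1N` has not yet been measured. It differs from compound 1 in one place: amino in place of trifluoromethyl on an aromatic carbon. In plain words, an amino group stands where the trifluoromethyl group stood, on the aromatic ring that carries the methyl group.

Going by the values given here, no measured pair shows this exact exchange, so the size of the step is open. The three measured compounds carry quite different groups on the core at that side and still land on similar numbers, which suggests the assay tolerates change in that region, but a change on the ring itself is a different matter. A modest loss is expected, and the step from compound 1 to compound 4 is estimated at a 2.4-fold higher number from compound 1 to compound 4 (0.38 log units; beyond the scatter) in this assay. Compound 4 is therefore expected to give about 70 nM, within a range from 15 nM to 350 nM.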

Compound 4, concentration for 50% growth inhibition: 3 nM
The estimate for compound 4 lay 23-fold (1.37 log units) above the measured number; the whole stated range lies above it.
By their numbers in this assay, from the lowest: compound 4; then compounds 1, 3 and 2 (each within the scatter of the next).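

In this assay, replacing trifluoromethyl with amino, ortho to a methyl group on the aromatic ring, gives a 9.7-fold lower number from compound 1 to compound 4 (0.99 log units; beyond the scatter), a step beyond the scatter. Going by these compounds alone, the earlier compounds offered no pair differing in one place, so this is the first direct sign that a single exchange at this spot can shift the read-out, and here the shift is towards stronger inhibition of growth. The two groups differ in heavy atoms as well as in hydrogen-bond donors and acceptors, but nothing shown identifies which of these differences matters, if any, and no supporting measurement is available to explain the gain.

The compounds shown leave open whether the gain comes from adding the amino group or simply from removing trifluoromethyl, a question that a plain hydrogen at this place could help to settle. They also leave open how much the amino group itself can be changed, and a hydroxyl group, a methylamino group or an acetamido group at the same carbon would test that.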